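Anilino in place of an oxazolyl amine: solubility expectation

The compounds below may be only part of what the source reports. "The series", "measured", "known", "first", "only" and "open" are said of these compounds alone.

Compound 1 `O=C(Nc1ccccc1)c1cnc(NCc2c(F)ccc3c2CCO3)n2cnnc12`: < 1000 nM (a limit of the assay)
Compound 2 `O=C(Nc1cnc(NCc2c(F)ccc3c2CCO3)n2cnnc12)c1ccccc1`: 2000 nM
Compound 3 `CN(c1ncco1)c1cnc(NCc2c(F)ccc3c2CCO3)n2cnnc12`: 67000 nM

Three compounds share one core and differ in the group on an aromatic carbon. In a physicochemical assay for solubility, read by LC-MS, in phosphate buffer, with a stated time of 24 h, at pH 7.4 (a higher number here means a more soluble compound, a lower number a less soluble compound), compound 1 gives only a limit, < 1000 nM. Compound 2 gives 2000 nM in this assay. Compound 3 stands highest of the two numbers shown, and a 34-fold higher number from compound 2 to compound 3 (1.53 log units; beyond the scatter); against the limit of compound 1 the step is an at least 67-fold higher number from compound 1 to compound 3 (1.82 log units; beyond the scatter) (the limit of < 1000 nM in this assay, at which 1 of the 3 values shown sits).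

Compound 4 `Fc1ccc2c(c1CNc1ncc(Nc3ccccc3)c3nncn13)CCO2` has not been measured. It differs from compound 3 in one place, (anilino in place of methyl(1,3-oxazol-2-yl)amino on an aromatic carbon). The two steps that bear on this change both lead to compound 3 and were large: an at least 67-fold higher number from compound 1 to compound 3 (1.82 log units; beyond the scatter) and a 34-fold higher number from compound 2 to compound 3 (1.53 log units; beyond the scatter). Compound 4 returns to a phenyl-bearing group with one hydrogen-bond donor, as in compounds 1 and 2, so a large step down in this assay is expected. Compound 4 is estimated at 5000 nM, between 1000 nM and 25000 nM, which would be an expected step of a 13-fold lower number from compound 3 to compound 4 (1.13 log units; beyond the scatter).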

Compound 4, solubility: 3000 nM
Compound 4: middle estimate off by 1.7-fold (0.22 log units), on the high side, within the range that was stated.
By their numbers in this assay, from the lowest: compounds 2 and 4 (each within the scatter of the next); then compound 3. At a limit, below all of these: compound 1.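

In this assay, the step at this position is large: a 22-fold lower number from compound 3 to compound 4 (1.35 log units; beyond the scatter). Compound 4 has no carbonyl in its side group, unlike compound 2, yet the two cannot be told apart, since a 1.5-fold higher number from compound 2 to compound 4 (0.18 log units; within the scatter), so removing that carbonyl alone does not reach the high number of compound 3. Compound 1 stands only as a limit, and the step of an at least 3.0-fold higher number from compound 1 to compound 4 (0.47 log units; beyond the scatter) is read against it: the limit of < 1000 nM in this assay, at which 1 of the 4 values shown sits.

From the compounds shown here alone, it stays open whether the large step follows the oxazole ring, the methyl on the nitrogen, or the hydrogen-bond donor that anilino brings. A methyl(phenyl)amino group or a plain (1,3-oxazol-2-yl)amino group at this position would begin to separate these, and a saturated amine such as morpholine would show whether an aromatic ring is needed there at all.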